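Adding 2-hydroxyethyl to an unsubstituted aromatic carbon

This account rests on a few compounds, and the source may have more. Where it says the series, first, only, none or still open, it means among the compounds named here.

In a functional assay on CFPAC-1 cells (Homo sapiens) for antiproliferative activity, read by MTT assay, with a stated time of 72 h (on this read-out higher numbers stand for weaker inhibition and lower numbers for stronger inhibition), compound 3 `O=C1O[C@H]([C@@H](O)Cn2ccnn2)C(OCc2ccccc2)=C1OCc1ccccc1` gives no number, only a limit of the assay: > 100000 nM (the limit of > 100000 nM in this assay, at which 1 of the 3 values shown sits). Compound 4 `O=C1O[C@H]([C@@H](O)Cn2cc(CCO)nn2)C(OCc2ccccc2)=C1OCc1ccccc1` has 2-hydroxyethyl in place of hydrogen on an aromatic carbon.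

Two measured relatives carry a different group on that same carbon. In this assay, compound 1 `O=C1O[C@H]([C@@H](O)Cn2cc(CNS(=O)(=O)c3ccc(F)cc3)nn2)C(OCc2ccccc2)=C1OCc1ccccc1` gives 34700 nM, and compound 2 `O=C1O[C@H]([C@@H](O)Cn2cc(CCCCl)nn2)C(OCc2ccccc2)=C1OCc1ccccc1` gives 58800 nM. Replacing those groups with hydrogen gives an at least 2.8-fold higher number from compound 1 to compound 3 (0.45 log units; beyond the scatter) and an at least 1.7-fold higher number from compound 2 to compound 3 (0.23 log units; that floor lies within the scatter). Both sizes are only floors, since compound 3 has no exact value.

Going by the values given here, compounds 1 and 2 are the only guides here, and their groups differ from 2-hydroxyethyl, so the expectation is cautious: a modest move towards stronger inhibition in this assay, the reverse direction of those two steps. The expected size is an at least 1.4-fold lower number from compound 3 to compound 4 (0.15 log units; that floor lies within the scatter). Another limit reading remains quite possible. For compound 4, the estimated value is 70000 nM, with an expected range of 35000 nM to 100000 nM.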

Compound 4, half-maximal inhibitory concentration: > 100000 nM
Compound 4: no number, only a limit; the forecaster's own chance of this, stated with the estimate: 40%; at least 1.4-fold (0.15 log units) between middle value and limit.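

Compound 4, like compound 3, sits at the limit of this assay, so the step between them cannot be read: the limit of > 100000 nM in this assay, at which 2 of the 4 values shown sit.

At this aromatic carbon, then, 2-hydroxyethyl shows no reading of stronger inhibition than hydrogen, so having just any chain at this position is not enough to bring a value under the limit. Measured against the ((4-fluorophenyl)sulfonyl)amino side chain, the new group gives an at least 2.8-fold higher number from compound 1 to compound 4 (0.45 log units; beyond the scatter), whereas against the 3-chloropropyl side chain it gives an at least 1.7-fold higher number from compound 2 to compound 4 (0.23 log units; that floor lies within the scatter).

As far as these compounds go, how far compound 3 and compound 4 lie beyond the limit, and whether they differ there, stays open. So does whether an amine or a carboxylic acid at the end of the chain, or a longer chain ending in hydroxy, would give a measurable value.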